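Swapping a Pyrazole Linkage on a Shared Core

The source may hold more compounds than are shown below. What is called first, only, known or untested is meant among the compounds shown, and "the series" means these compounds.

Measured compounds:
- compound 1, `Cn1cc(-c2cnc3[nH]cc(-c4cccc(C(F)(F)F)c4)c3c2)cn1`: 1000 nM
- compound 2, `Cn1cc(-c2cnc3[nH]cc(C4CCCN(C(=O)OC(C)(C)C)C4)c3c2)cn1`: 17000 nM
- compound 3, `Cc1nn(C)c(C)c1-c1cnc2[nH]cc(-c3cccc(C#N)c3)c2c1`: 5700 nM

In a physicochemical assay for solubility, read by LC-MS, in phosphate buffer, measured as thermodynamic solubility, with a stated time of 24 h, at pH 7.4 (a higher number here means a more soluble compound, a lower number a less soluble compound), compound 3 stands second of the three numbers, with compound 2 giving a higher value and compound 1 a lower one, both gaps beyond the scatter. Compound 4, `Cn1cc(Nc2cnc3[nH]cc(-c4cccc(C#N)c4)c3c2)cn1`, has not yet been measured. It differs from compound 3 in one place: (1-methyl-1H-pyrazol-4-yl)amino in place of 1,3,5-trimethyl-1H-pyrazol-4-yl on an aromatic carbon. Among the compounds with values here, no measured pair shows this exact change, so the expectation rests on compound 3 alone. A modest upward step is expected, a 1.4-fold higher number from compound 3 to compound 4 (0.15 log units; within the scatter), though a step within the scatter would not surprise. Compound 4 is therefore estimated at 8000 nM, within a range from 2500 nM to 25000 nM.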

Compound 4, solubility: 31000 nM
The estimate for compound 4 lay 3.9-fold (0.59 log units) below the measured number, and the stated range ends below it.
By their numbers in this assay, from the lowest: compound 1; then compound 3; then compounds 2 and 4 (each within the scatter of the next).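

In this assay, replacing 1,3,5-trimethyl-1H-pyrazol-4-yl with (1-methyl-1H-pyrazol-4-yl)amino on this aromatic carbon of the shared core gives the first step measured at this position (a 5.4-fold higher number from compound 3 to compound 4 (0.74 log units; beyond the scatter)). The change adds an amino link and removes ring methyl groups at once, and this one pair cannot separate the two. No measurement shown here explains the rise.

Which part of the change carries the step stays open. So does how an ether oxygen or a methylamino link would compare at this position.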